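Ketone in place of a thioester on a shared core

A few compounds are considered here, and "the series" means these few. Any claim that something is new, unique, unknown or untested is made for them only; others in the source may bear on it.

Three compounds share one core and differ only at the carbonyl end. Compound 1 `CCCCOC(=O)/C=C(C)/C=C/CC(C)CCCC(C)(C)OC` gives 6.62 in a physicochemical assay for lipophilicity; a lower number here means a more polar compound, a higher number a more lipophilic compound; compound 2 `C=CCOC(=O)/C=C(C)/C=C/CC(C)CCCC(C)(C)OC` gives 5.53; compound 3 `CCSC(=O)/C=C(C)/C=C/CC(C)CCCC(C)(C)OC` gives 6.78, the highest of the three, with a number 0.16 log units higher from compound 1 to compound 3 (within the scatter) and a number 1.25 log units higher from compound 2 to compound 3 (beyond the scatter). Compound 4 `CCC(C)C(=O)/C=C(C)/C=C/CC(C)CCCC(C)(C)OC` carries a change at the same place: sec-butyl in place of ethylsulfanyl on a carbonyl carbon. Among the measured compounds shown here, no measured step swaps a sulfur-bearing group for a carbon chain here; the nearest guide is the swap on the carbonyl carbon, a number 0.16 log units higher from compound 1 to compound 3 (within the scatter), which stayed within the scatter, whereas a number 1.09 log units lower from compound 1 to compound 2 (beyond the scatter) changed a chain on oxygen. For compound 4 a step of about a number 0.07 log units higher from compound 3 to compound 4 (within the scatter) is therefore expected, within the scatter. Compound 4 is estimated at 6.85, between 6.35 and 7.35.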

Compound 4, partition coefficient: 6.02
The estimate for compound 4 lay 0.83 log units above the measured number, and the stated range ends above it.
By their numbers in this assay, from the lowest: compound 2; then compound 4; then compounds 1 and 3 (each within the scatter of the next).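

In this assay sec-butyl in place of ethylsulfanyl gives a number 0.76 log units lower from compound 3 to compound 4 (beyond the scatter) and in place of butoxy gives a number 0.60 log units lower from compound 1 to compound 4 (beyond the scatter) while in place of allyloxy it gives a number 0.49 log units higher from compound 2 to compound 4 (beyond the scatter) on the same carbonyl carbon. Butoxy and ethylsulfanyl had looked interchangeable at this position, but this all-carbon group does not fall within the scatter of either, so not every group placed here gives the same number. No available evidence accounts for these steps. The compounds shown leave open how a longer carbon chain or an amine on this carbonyl carbon would compare with sec-butyl.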